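Replacing a Sulfonamide by Pyridine on the Indane Core

A few compounds are considered here, and "the series" means these few. Any claim that something is new, unique, unknown or untested is made for them only; others in the source may bear on it.

The series rests on a shared core carrying an imidazole on the saturated ring. Compound 1 `CCCS(=O)(=O)Nc1cccc2c1CCC2c1ncc[nH]1` gives 54% in a functional assay on CHO cells for agonist activity at Alpha-1A adrenergic receptor (Homo sapiens), read by FLIPR and calcium flux; on this read-out higher numbers stand for larger maximal responses and lower numbers for smaller maximal responses. Compound 2 `CS(=O)(=O)Nc1cccc2c1CCC2c1ncc[nH]1` gives 87% in the same assay, and it stands highest of the two numbers, with a step of a number 33 percentage points higher from compound 1 to compound 2 (beyond the scatter). Compound 3 `c1cncc(-c2cccc3c2CCC3c2ncc[nH]2)c1` is not yet measured; it differs from compound 2 by pyridin-3-yl in place of methanesulfonamido on an aromatic carbon. Going by the values given here, the only measured step, from compound 1 to compound 2, changes the chain on the sulfonyl sulfur and keeps the sulfonamide itself, so it bears only loosely on a change that removes the whole methanesulfonamido group. Among the compounds with values here, no measured pair shows the effect of an aromatic ring in that position. The expectation for compound 3 is therefore a downward step of a number 27 percentage points lower from compound 2 to compound 3 (beyond the scatter) with wide uncertainty, since the donor of compound 2 is lost. Compound 3 is estimated at 60%, with a range from 25% to 95%.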

Compound 3, largest response reached (Emax), in percent of the reference or control that the assay uses: 36%
Beside the measured number, compound 3's estimate is 24 percentage points above it; measured number inside the range.
By their numbers in this assay, from the lowest: compound 3; then compound 1; then compound 2.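

Pyridin-3-yl on this aromatic carbon falls short of both sulfonamides: in this assay the exchange for methanesulfonamido gives a number 51 percentage points lower from compound 2 to compound 3 (beyond the scatter), and the exchange for (propylsulfonyl)amino gives a number 18 percentage points lower from compound 1 to compound 3 (beyond the scatter). The earlier pair varied only the chain on the sulfonyl sulfur, whereas these steps show that replacing the whole group at this position also moves the maximal response, although compound 3 still reaches 36%. Nothing available here accounts for the loss.

The compounds shown leave open whether the drop comes from losing the sulfonamide or from adding pyridin-3-yl, since the two happen in one change. A phenyl ring, a pyridin-4-yl ring or a simple amine on the same aromatic carbon would help to separate these two parts.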